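From Iodo to Methoxy on a Shared Core

The source may hold more compounds than are shown below. What is called first, only, known or untested is meant among the compounds shown, and "the series" means these compounds.

Among the compounds with values here, in a functional assay on NCI-H460 cells (Homo sapiens) for inhibition (a higher number here means a weaker inhibitor of growth, a lower number a stronger inhibitor of growth), compound 2 (`NC(=O)c1cc(I)ccc1NC(=O)COc1ccccc1`) gives 425 nM and holds the lower of the two numbers so far. Compound 1 (`NC(=O)c1cc(Cl)ccc1NC(=O)COc1ccccc1`) gives 3000 nM on the same read-out. Within the data shown here, only one measured step bears on what follows: iodo in place of chloro on an aromatic carbon gave a 7.1-fold lower number from compound 1 to compound 2 (0.85 log units; beyond the scatter) as a modest change. Compound 3 (`COc1ccc(NC(=O)COc2ccccc2)c(C(N)=O)c1`) now carries methoxy in place of iodo on that aromatic carbon (methoxy in place of iodo on an aromatic carbon). Among the measured compounds shown here, no methoxy compound has been measured, so the guide is thin. The expectation rests on a 7.1-fold lower number from compound 1 to compound 2 (0.85 log units; beyond the scatter) alone, read in reverse, with iodo leaving and the number going back up. The estimated change is a 4.2-fold higher number from compound 2 to compound 3 (0.63 log units; beyond the scatter) in this assay and would lie beyond the scatter. For compound 3 the estimate is 1800 nM within an expected range from 600 nM to 5000 nM for now.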

Compound 3, concentration for 50% growth inhibition: 484 nM
Compound 3: the middle estimate sits 3.7-fold (0.57 log units) above what was measured; the measured number lies below the stated range.
By their numbers in this assay, from the lowest: compounds 2 and 3 (each within the scatter of the next); then compound 1.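

Within the data shown here, at this position on the shared core, iodo is not the only group that reaches the lower numbers in this assay: methoxy in its place gave a 1.1-fold higher number from compound 2 to compound 3 (0.06 log units; within the scatter), so the two cannot be told apart here. Methoxy also holds the advantage over chloro, with a 6.2-fold lower number from compound 1 to compound 3 (0.79 log units; beyond the scatter), which leaves chloro as the one group of the three that stands apart. Iodo and methoxy share this result even though they differ in their atoms, in heavy-atom count and in hydrogen-bond acceptor count.

Nothing available explains why the three groups fall as they do. As far as these compounds go, whether an amine, a carboxylic acid or a longer chain such as ethoxy at this position would sit with compound 2 and compound 3 or with compound 1 remains open.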